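Acyl variation on the hydroxamate of a benzofuran series

This account rests on a few compounds, and the source may have more. Where it says the series, first, only, none or still open, it means among the compounds named here.

Measured compounds:
compound 1, `CC(=O)N(O)C(C)c1ccc(OCCc2ccccc2)cc1`, 410 nM
compound 2, `CCCCCCCCCCc1cc2cc(C(C)N(O)C(C)=O)ccc2o1`, 410 nM
compound 3, `COc1cccc(OC)c1C(=O)N(O)C(C)c1ccc2oc(-c3ccccc3)cc2c1`, 3000 nM

In an assay on RBL cells for inhibition of Polyunsaturated fatty acid 5-lipoxygenase (Rattus norvegicus) (on this read-out lower numbers stand for stronger inhibition and higher numbers for weaker inhibition), compound 1 gives 410 nM and compound 2 gives 410 nM; these two values lie within the scatter of each other. Compound 3 stands apart: in this assay compound 3 gives 3000 nM, the highest of the three numbers, and its gap to either of the other two lies beyond the scatter. Compound 1 and compound 2 both carry an acetyl on the hydroxamate nitrogen, while compound 3 carries the aroyl group.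

The next compound, compound 4, `COC(=O)CCCC(=O)N(O)C(C)c1ccc2oc(-c3ccccc3)cc2c1`, changes only this acyl part: 3-(methoxycarbonyl)propyl in place of 2,6-dimethoxyphenyl on a carbonyl carbon. Within the data shown here, no step between measured compounds covers this exact exchange, so the expectation rests on the contrast between compound 3 and the two acetyl compounds. A chain acyl moves compound 4 toward the acetyl pattern of compound 1 and compound 2, so a drop in this assay beyond the scatter is expected, though not necessarily all the way down to the acetyl values. Compound 4 is therefore estimated at 900 nM, with a range of 300 nM to 2700 nM. The expected step is a 3.3-fold lower number from compound 3 to compound 4 (0.52 log units; beyond the scatter).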

Compound 4, half-maximal inhibitory concentration: 60 nM
The estimate for compound 4 lay 15-fold (1.18 log units) above the measured number; measured number below the stated range.
By their numbers in this assay, from the lowest: compound 4; then compounds 1 and 2 (each within the scatter of the next); then compound 3.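

In this assay, the exchange of 2,6-dimethoxyphenyl for 3-(methoxycarbonyl)propyl on a carbonyl carbon whose other neighbour is the amide-type nitrogen gives a 50-fold lower number from compound 3 to compound 4 (1.70 log units; beyond the scatter), so this position alone, with the shared core held constant, can move the number far beyond the scatter. The earlier compounds shown here could not show this, since the acetyl compounds also differ from compound 3 elsewhere in the structure, whereas this pair isolates the acyl part and shows that a ring-free chain ending in an ester is accepted here with a much lower number than the 2,6-dimethoxyphenyl group. The hydrogen-bond donor and acceptor counts are the same for the two groups, so those counts do not follow the change, and nothing measured here accounts for the size of the step.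

Going by these compounds, it remains open whether the lower number goes with the removal of the aromatic ring or with the ester at the end of the chain. A plain pentyl chain and a carboxylic acid in place of the ester, each on the same core, would separate these two readings.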